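Thiol to methylselanyl on the shared core of compound 1

The compounds below may be only part of what the source reports. "The series", "measured", "known", "first", "only" and "open" are said of these compounds alone.

For the measured compounds named here, compound 1 `Sc1nc(NCc2ccccc2)c2ccccc2n1` is the only compound here with a measured number. In a functional assay on HTB-54 cells (Homo sapiens) for cytotoxicity, read by MTT assay, with a stated time of 72 h (a higher number here means a weaker inhibitor of growth, a lower number a stronger inhibitor of growth), compound 1 gives 15200 nM. Compound 2 `COc1ccc(CNc2nc(SC)nc3ncccc23)cc1` belongs to a different core and in this assay compound 2 reaches only a limit, > 100000 nM; this limit is one of the two values shown the limit of > 100000 nM in this assay, at which 1 of the 2 values shown sits, and is not a number. Going by the values given here, no step between two measured compounds is available, so the size of the change from compound 1 to compound 3 `C[Se]c1nc(NCc2ccccc2)c2ccccc2n1` has no measured precedent. The change is a group of 2 heavy atoms (1 carbon, 1 selenium; no ring) in place of one sulfur atom, on an aromatic carbon, on the same aromatic carbon of the core of compound 1. Among the compounds with values here, with no comparable step in hand, only a modest move is expected, if any beyond the scatter, and the expected direction is toward a somewhat stronger inhibitor of growth. For compound 3 the estimate in this assay is 8000 nM, with a range from 2500 nM to 30000 nM, which means an expected step of a 1.9-fold lower number from compound 1 to compound 3 (0.28 log units; within the scatter).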

Compound 3, concentration for 50% growth inhibition: 74600 nM
Compound 3: the middle estimate sits 9.3-fold (0.97 log units) below what was measured; measured number outside the range, above it.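

In this assay the replacement of sulfanyl by the methylselanyl group gives a 4.9-fold higher number from compound 1 to compound 3 (0.69 log units; beyond the scatter), the first step read at this position, and it runs toward a weaker inhibitor of growth. The aromatic carbon between two ring nitrogen atoms is therefore not indifferent to what it carries, at least for this pair on the shared core. No measured property in hand accounts for the step.

For the compounds shown here, the single step changes the atom on the ring and adds a carbon at once, so the contribution of each stays unresolved. Going by these compounds, how a longer chain such as ethylselanyl, or an amine, on the same carbon would read in this assay remains open, as does whether the direction of this step holds for other groups at this position.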